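Thiophene regioisomers on two dihydropyrimidine cores at A2b

This account rests on a few compounds, and the source may have more. Where it says the series, first, only, none or still open, it means among the compounds named here.

Compound 1 `COC(=O)C1=C(C)NC(=S)NC1c1cccs1` gives 10% in an assay on membranes from HEK293 cells for displacement of a labelled ligand from adenosine receptor A2b (Homo sapiens), read by scintillation counting, with a stated time of 30 min, tested at 1 uM; on this read-out lower numbers stand for less inhibition and higher numbers for more inhibition at the one concentration tested (going by the name of the read-out). Compound 2 `COC(=O)C1=C(C)NC(=S)NC1c1ccsc1` carries the change thiophen-3-yl in place of thiophen-2-yl on a saturated ring carbon and gives 38%; this step, a number 28 percentage points higher from compound 1 to compound 2 (beyond the scatter), is beyond the scatter. Compound 3 `COC(=O)C1=C(C)N(C)C(=O)NC1c1cccs1` rests on a different core; the difference between the two cores is not broken down here. In this assay compound 3 gives 17%, within the scatter of compound 1 and beyond the scatter of compound 2. Compound 4 `COC(=O)C1=C(C)N(C)C(=O)NC1c1ccsc1` is not yet measured; it differs from compound 3 by thiophen-3-yl in place of thiophen-2-yl on a saturated ring carbon, the same kind of change as that from compound 1 to compound 2, though here the place is also three ring bonds from the ring atom that bears a methyl group. Among the measured compounds shown here, because the earlier step of a number 28 percentage points higher from compound 1 to compound 2 (beyond the scatter) was modest and beyond the scatter, a step of similar direction is expected, a number 20 percentage points higher from compound 3 to compound 4 (beyond the scatter), with the single precedent as its only basis. Compound 4 is estimated at 37% in this assay, between 20% and 55%.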

Compound 4, a percentage reported as inhibition, at one concentration (the size of the read-out at that concentration, not a potency): 26%
Compound 4: the middle estimate sits 11 percentage points above what was measured, within the range that was stated.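

On the core of compound 3, the change from thiophen-2-yl to thiophen-3-yl gives a number 9 percentage points higher from compound 3 to compound 4 (within the scatter) in this assay, so no gain can be claimed there. Set beside the step on the core of compound 1, the size of the change does not carry over between the two cores: the same change on two cores in this assay, a number 28 percentage points higher (beyond the scatter) from compound 1 to compound 2 and a number 9 percentage points higher (within the scatter) from compound 3 to compound 4, 19 percentage points apart, beyond the scatter of two such steps This does not show that the change is without effect on the core of compound 3, and with one pair per core it gives no general rule or says which difference between the cores matters.

Going by these compounds, all four compounds share the methoxycarbonyl group, so it remains open whether either step holds with a carboxylic acid or an amide there. On these data alone, a phenyl ring in place of the thiophenes also remains open.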